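The source may report more compounds than this note shows. Statements on the series, on what has been measured and on what is new or still open speak of the compounds shown alone.

In a functional assay on cells (Cancer cell lines, Homo sapiens) for inhibition (on this read-out lower numbers stand for stronger inhibition of growth and higher numbers for weaker inhibition of growth), compound 1 `N=C(N)N/N=C/c1c(-c2cc(Cl)sc2Cl)nc2n1CCS2` gives 8130 nM. Compound 2 `Cc1cc(-c2nc3sccn3c2/C=N/NC(=N)N)c(C)s1` gives 13800 nM. These two numbers lie within the usual scatter of each other, so compound 1 cannot be told apart from compound 2. Compound 3 `N=C(N)N/N=C/c1c(-c2ccsc2)nc2n1CCS2` carries thiophen-3-yl in place of 2,5-dichlorothiophen-3-yl on an aromatic carbon. Among the measured compounds shown here, no pair of measured compounds shows this change, so any expectation is rough. In this assay, a small step towards a higher number is expected, a 1.8-fold higher number from compound 1 to compound 3 (0.27 log units; within the scatter). The estimate for compound 3 is 15000 nM, with an expected range from 5000 nM to 45000 nM.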

Compound 3, concentration for 50% growth inhibition: 17400 nM
Compound 3: middle estimate off by 1.2-fold (0.06 log units), on the low side; measured number inside the range.
By their numbers in this assay, from the lowest: compounds 1, 2 and 3 (each within the scatter of the next, the first and the last beyond it).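

Among the compounds shown here, with thiophen-3-yl in place of 2,5-dichlorothiophen-3-yl, this assay shows a 2.1-fold higher number from compound 1 to compound 3 (0.33 log units; beyond the scatter) on this core, the first step beyond the scatter in this set. This aromatic carbon therefore responds to the chlorine-bearing thiophene, but only modestly, and compound 1 keeps the lower number. No measurement here explains the step. On these data alone, it remains open whether a single chlorine, as in 5-chlorothiophen-3-yl, would give the same result, and how a phenyl or pyridine ring would behave at this position.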